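The source may report more compounds than this note shows. Statements on the series, on what has been measured and on what is new or still open speak of the compounds shown alone.

In a physicochemical assay for lipophilicity, using the shake flask method, in phosphate buffer, measured as octanol-water partition, with a stated time of 30 min, at pH 7.4 (on this read-out higher numbers stand for higher lipophilicity and lower numbers for lower lipophilicity), compound 1 (`O=C1c2ccccc2CN1c1cnc(NCc2c(F)ccc3c2CCO3)n2cnnc12`) gives 2.7 and compound 2 (`Cc1nc(CO)ccc1-c1cnc(NCc2c(F)ccc3c2CCO3)c2cn[nH]c(=O)c12`) gives 2.4, two values that lie within the usual scatter of each other. Compound 3 (`Cc1cc(-c2cnc(NCc3c(F)ccc4c3CCO4)c3cn[nH]c(=O)c23)n(C)n1`) keeps the core of compound 2 but carries 1,3-dimethyl-1H-pyrazol-5-yl in place of 6-(hydroxymethyl)-2-methylpyridin-3-yl on an aromatic carbon. Going by the values given here, no measured pair of compounds shows what such an exchange does in this assay, so this expectation is only tentative. A small upward step, about the size of the usual scatter, is expected (a number 0.30 log units higher from compound 2 to compound 3 (within the scatter)). The estimated value for compound 3 is 2.7 (expected range 2.2 to 3.2).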

Compound 3, distribution coefficient: 3
Estimate against measurement, compound 3: 0.30 log units below; the range from low to high includes it.
By their numbers in this assay, from the lowest: compounds 2, 1 and 3 (each within the scatter of the next, the first and the last beyond it).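

Changing only the group on this aromatic carbon of the shared core gives a number 0.60 log units higher from compound 2 to compound 3 (beyond the scatter) in this assay, so the group at this position can move the reading by more than the usual scatter. The entering 1,3-dimethyl-1H-pyrazol-5-yl has 0 hydrogen-bond donors, while the leaving 6-(hydroxymethyl)-2-methylpyridin-3-yl has 1, but this exchange also alters the ring and its other substituents. Nothing available ties the step to any one of these differences.

The compounds shown leave open how a carboxylic acid or an amine such as morpholine would read at this position. They also leave open whether the same exchange would give a similar step on the core of compound 1.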